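The source may hold more compounds than are shown below. What is called first, only, known or untested is meant among the compounds shown, and "the series" means these compounds.

Compound 3 `CC(C(=O)NCc1ccc(C(F)(F)F)nc1N1CCC(=O)CC1)c1ccc(NS(C)(=O)=O)c(F)c1` carries a 4-oxopiperidin-1-yl group on the shared core and gives 91 nM in a functional assay on CHO-K1 cells for antagonist activity at transient receptor potential cation channel subfamily V member 1 (Homo sapiens), read by FLIPR (a higher number here means a weaker inhibitor, a lower number a stronger inhibitor), the highest number among the three measured compounds. Compound 1 `CC(C(=O)NCc1ccc(C(F)(F)F)nc1NCc1ccc(Cl)cc1)c1ccc(NS(C)(=O)=O)c(F)c1` gives 65.7 nM in this assay, and the step of a 1.4-fold higher number from compound 1 to compound 3 (0.14 log units; within the scatter) lies within the scatter, so these two compounds cannot be ordered. For the measured compounds named here, compound 2 `CC(C(=O)NCc1ccc(C(F)(F)F)nc1N1CCC(C(=O)c2ccc(F)cc2)CC1)c1ccc(NS(C)(=O)=O)c(F)c1` gives 3.9 nM; no single step joins it to compound 3, but the two values stand far apart, beyond the scatter, and compound 2 differs from compound 3 only in what sits on the piperidine ring.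

Compound 4 `CCCCOC1CCN(c2nc(C(F)(F)F)ccc2CNC(=O)C(C)c2ccc(NS(C)(=O)=O)c(F)c2)CC1` has not been measured in this assay. The change is a group of 11 heavy atoms (9 carbon, 1 nitrogen, 1 oxygen; one six-membered non-aromatic ring with 1 hetero atom) in place of a group of 7 heavy atoms (5 carbon, 1 nitrogen, 1 oxygen; one six-membered non-aromatic ring with 1 hetero atom), on an aromatic carbon, placed next to the ring nitrogen, ortho to a large group and meta to the trifluoromethyl group. Going by the values given here, the one step measured at this position on the core was within the scatter. Among the compounds with values here, the only guidance toward a larger piperidine substituent comes from compound 2, whose value of 3.9 nM is far lower; a single pair is not a pattern. For compound 4 a moderate step down is expected, a 3.6-fold lower number from compound 3 to compound 4 (0.56 log units; beyond the scatter). The number for compound 4 is estimated at 25 nM, between 7 nM and 90 nM.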

Compound 4, inhibition constant: 3.5 nM
Estimate against measurement, compound 4: 7.1-fold (0.85 log units) above; the whole stated range lies above it.
By their numbers in this assay, from the lowest: compounds 4 and 2 (each within the scatter of the next); then compounds 1 and 3 (each within the scatter of the next).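

For the compounds shown here, at this position on the shared core the one earlier step stayed within the scatter, yet a 26-fold lower number from compound 3 to compound 4 (1.41 log units; beyond the scatter) and a 19-fold lower number from compound 1 to compound 4 (1.27 log units; beyond the scatter) both come with the butoxy-substituted piperidine in this assay and show that the position does respond to its substituent. With a 1.1-fold lower number from compound 2 to compound 4 (0.05 log units; within the scatter) the butoxy and (4-fluorophenyl)carbonyl groups cannot be ordered, so compound 2 no longer stands alone: two very different groups on the saturated ring carbon both give values far lower than the 4-oxopiperidin-1-yl group of compound 3. Nothing measured here explains the drop.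

Open, going by these compounds, is whether chain length matters on that ring carbon, which methoxy or hexyloxy in place of butoxy would test. Also open, on these data alone, is how an amine or a carboxylic acid there would read in this assay.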